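Replacing 2-Ethylpiperidin-1-yl with Cyclopropyl(propyl)amino

The source may report more compounds than this note shows. Statements on the series, on what has been measured and on what is new or still open speak of the compounds shown alone.

Of the compounds shown here, three sharing one core have been measured in an assay on cell membranes for displacement of a labelled ligand from corticotropin-releasing factor receptor 1 (Rattus norvegicus); a lower number here means a stronger inhibitor, a higher number a weaker inhibitor. Compound 1 `CCC1CCCCN1c1nc(C)nc2c(-c3c(C)cc(OC)cc3OC)c(C)nn12` gives 3.26 nM. Compound 2 `CCC(CC)Nc1nc(C)nc2c(-c3cc(F)c(OC)cc3C)c(C)nn12` gives 1.9 nM, and compound 3 `CCCN(CCC#N)c1nc(C)nc2c(-c3ccc(OC)cc3C)c(C)nn12` gives 2.16 nM. All three numbers fall within the usual scatter of one another, so compound 1 cannot be told apart from compound 2 or compound 3 on these results.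

Compound 4 `CCCN(c1nc(C)nc2c(-c3c(C)cc(OC)cc3OC)c(C)nn12)C1CC1` carries a different amine on the same aromatic carbon: cyclopropyl(propyl)amino in place of 2-ethylpiperidin-1-yl on an aromatic carbon. Within the data shown here, since no measured pair shows what such a swap does, and since all three measured amines give similar numbers, only a small step is expected, from compound 1 to compound 4 a 1.1-fold lower number from compound 1 to compound 4 (0.04 log units; within the scatter), not beyond the scatter. For compound 4 a value near 3 nM is estimated, between 1 nM and 10 nM.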

Compound 4, half-maximal inhibitory concentration: 1.48 nM
Beside the measured number, compound 4's estimate is 2.0-fold (0.31 log units) above it, and the stated range covers the measured number.
By their numbers in this assay, from the lowest: compounds 4, 2, 3 and 1 (each within the scatter of the next, the first and the last beyond it).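

In this assay, among these compounds, the amine on the aromatic carbon between two ring nitrogen atoms can be compared directly for the first time, and the swap gives a 2.2-fold lower number from compound 1 to compound 4 (0.34 log units; beyond the scatter) with cyclopropyl(propyl)amino in place of 2-ethylpiperidin-1-yl. The step is modest, but it shows that changing this amine alone can move the number beyond the scatter. No available evidence explains the difference.

As far as these compounds go, whether the same swap gives a similar step with the other aromatic groups remains open. So does the effect of a dipropylamino or morpholin-4-yl group at this position.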